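From compound 3 to compound 4: hydroxy to ((2-carboxyethyl)carbonyl)oxy

The compounds below may be only part of what the source reports. "The series", "measured", "known", "first", "only" and "open" are said of these compounds alone.

In a functional assay on HepG2 cells (Homo sapiens) for cytotoxicity, read by MTT assay, with a stated time of 72 h (a lower number here means a stronger inhibitor, a higher number a weaker inhibitor), compound 3 (`Cc1c(C)c2c(c(C)c1O)CCC(C)(C(=O)NC1CC(C)(C)N([O])C1(C)C)O2`) gives 145000 nM as the highest of the two numbers, and compound 2 (`Cc1c(C)c2c(c(C)c1O)CCC(C)(C(=O)NC1CC(C)(C)N([O])C(C)(C)C1)O2`) gives 54000 nM as the other, a gap beyond the scatter. Compound 1 (`Cc1c(C)c2c(c(C)c1OC(=O)CCC(=O)O)CCC(C)(C(=O)NC1CC(C)(C)N([O])C(C)(C)C1)O2`) gives > 300000 nM as a limit of the assay and not a number.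

Compound 4 (`Cc1c(C)c2c(c(C)c1OC(=O)CCC(=O)O)CCC(C)(C(=O)NC1CC(C)(C)N([O])C1(C)C)O2`) carries (2-carboxyethyl)carbonyl in place of hydrogen on an oxygen on an aromatic ring. Among the measured compounds shown here, the one measured step bearing on this is the same change read in reverse, an at least 5.5-fold lower number from compound 1 to compound 2 (0.74 log units; beyond the scatter) with hydrogen in place of (2-carboxyethyl)carbonyl. Carried over to compound 3, that step points to a higher number, beyond the scatter. Compound 4 is expected to have a good chance of reading at the limit of > 300000 nM in this assay, at which 1 of the 3 values shown sits, rather than as a number. The expected change is a 3.4-fold higher number from compound 3 to compound 4 (0.54 log units; beyond the scatter) as an estimate, towards a higher number. In this assay the estimated value for compound 4 is 500000 nM with 250000 nM and 1200000 nM as the expected ends of the range.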

Compound 4, half-maximal inhibitory concentration: > 300000 nM
Compound 4 was reported as a limit; the forecaster's own chance of this, stated with the estimate: 75%; the middle value is on the limit's open side.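

Placing (2-carboxyethyl)carbonyl on the oxygen on the aromatic ring gives an at least 2.0-fold higher number from compound 3 to compound 4 (0.31 log units; beyond the scatter) in this assay, so the direction seen on the core of compound 2 also holds on the core of compound 3. The direction agrees across the two cores, but the size cannot be compared: the same change on two cores in this assay, an at least 5.5-fold lower number (0.74 log units; beyond the scatter) from compound 1 to compound 2 and an at least 2.0-fold lower number (0.31 log units; beyond the scatter) from compound 4 to compound 3; the limit leaves it open whether they differ The step between compound 1 and compound 4 joins two limits and cannot be read, so the five-membered and six-membered non-aromatic rings stay unranked among compounds carrying this group: the limit of > 300000 nM in this assay, at which 2 of the 4 values shown sit.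

Open, on these data alone, is whether a shorter acetyl group on the same oxygen would return a measurable number on either core. Also open, as far as these compounds go, is whether an amine in place of the terminal carboxylic acid would do so.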